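One Fluoro More on the Trifluoromethylphenyl Side

The source may report more compounds than this note shows. Statements on the series, on what has been measured and on what is new or still open speak of the compounds shown alone.

Compound 2 `O=C(Nc1ccc(Oc2ccc(-c3nccs3)cc2)cc1)Nc1cccc(C(F)(F)F)c1` gives 5560 nM in a functional assay on A549 cells (Homo sapiens) for inhibition, read by MTT assay and WST assay, with a stated time of 72 h (a lower number here means a stronger inhibitor, a higher number a weaker inhibitor), at one end of the two numbers measured, while compound 1 `O=C(Nc1ccc(Oc2ccc(-c3nccs3)cc2)cc1)Nc1ccc(Cl)c([N+](=O)[O-])c1` gives 3890 nM, and a 1.4-fold higher number from compound 1 to compound 2 (0.16 log units; within the scatter). Compound 3 `O=C(Nc1ccc(Oc2ccc(-c3nccs3)cc2)cc1)Nc1ccc(F)c(C(F)(F)F)c1` is compound 2 with fluoro in place of hydrogen on an aromatic carbon. Going by the values given here, no measured step bears directly on this change: the single step known swaps the whole aryl group and stays within the scatter, so a small added fluoro offers no ground for a shift beyond it. For compound 3 the expected step is a 1.1-fold lower number from compound 2 to compound 3 (0.05 log units; within the scatter). Compound 3 is therefore estimated at 5000 nM, with a range from 2200 nM to 11000 nM.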

Compound 3, half-maximal inhibitory concentration: 4980 nM
Estimate against measurement, compound 3: 1.0-fold (0.00 log units) above, within the range that was stated.
By their numbers in this assay, from the lowest: compounds 1, 3 and 2 (each within the scatter of the next).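

Placing fluoro on this aromatic carbon, ortho to the trifluoromethyl group, gives a 1.1-fold lower number from compound 2 to compound 3 (0.05 log units; within the scatter) in this assay and so adds a single fluorine without a shift beyond the scatter. Exchanging the whole 4-chloro-3-nitrophenyl group for 4-fluoro-3-(trifluoromethyl)phenyl gives a 1.3-fold higher number from compound 1 to compound 3 (0.11 log units; within the scatter) and also stays within the scatter, so these three aryl groups cannot be told apart here. No evidence is available to explain this result.

Going by these compounds, whether a larger group on this same carbon, such as a methoxy group or an amine, would also stay within the scatter remains open.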